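The source may hold more compounds than are shown below. What is called first, only, known or untested is meant among the compounds shown, and "the series" means these compounds.

Measured in a functional assay on HCT-15 cells (Homo sapiens) for antiproliferative activity; a higher number here means a weaker inhibitor of growth, a lower number a stronger inhibitor of growth:
Compound 1 `c1ccc(-c2cc(-c3ccccn3)nc(-c3ccccn3)c2)cc1`: 0.37 ug/mL
Compound 2 `c1ccc(-c2cc(-c3cccs3)cc(-c3ccccn3)n2)nc1`: 0.11 ug/mL

Of these two, compound 2 stands lowest at 0.11 ug/mL, and so is the stronger inhibitor of growth. Compound 3 `c1ccc(-c2cc(-c3cccs3)cc(-c3ccncc3)n2)nc1` has not yet been measured. It differs from compound 2 by one change: pyridin-4-yl in place of pyridin-2-yl on an aromatic carbon, next to the ring nitrogen (pyridin-4-yl in place of pyridin-2-yl on an aromatic carbon). For the measured compounds named here, the only measured step is a 3.4-fold lower number from compound 1 to compound 2 (0.53 log units; beyond the scatter), which came with thiophen-2-yl in place of phenyl. That is a different change, so it offers a guide to size and none to direction. Going by the values given here, no measured step covers the pyridinyl swap. With compound 2 at the low end of this assay, a modest rise is expected, though this is held loosely. The estimated step is a 1.8-fold higher number from compound 2 to compound 3 (0.26 log units; within the scatter). For compound 3 the expected value is 0.2 ug/mL, with an estimated range from 0.06 ug/mL to 0.7 ug/mL.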

Compound 3, concentration for 50% growth inhibition: 15.1 ug/mL
Compound 3: middle estimate off by 76-fold (1.88 log units), on the low side, and the stated range ends below it.
By their numbers in this assay, from the lowest: compound 2; then compound 1; then compound 3.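

The change from pyridin-2-yl to pyridin-4-yl brings a 140-fold higher number from compound 2 to compound 3 (2.14 log units; beyond the scatter) in this assay, so this place on the shared core is highly sensitive to how the pyridine is joined, even though the two groups have the same atoms and the same counts of donors and acceptors. This step is far larger than the only earlier one, a 3.4-fold lower number from compound 1 to compound 2 (0.53 log units; beyond the scatter), which came with thiophen-2-yl in place of phenyl at a different place. Nothing available explains why the swap of pyridine attachment has so large an effect.

From the compounds shown here alone, whether pyridin-3-yl at this place would track with compound 2 or with compound 3 remains open. Also open, going by these compounds, is whether an amine on the pyridin-2-yl group of compound 2 would be tolerated.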